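A few compounds are considered here, and "the series" means these few. Any claim that something is new, unique, unknown or untested is made for them only; others in the source may bear on it.

In a functional assay on A549 cells (Homo sapiens) for antiproliferative activity, read by MTT assay, with a stated time of 48 h (a lower number here means a stronger inhibitor, a higher number a weaker inhibitor), compound 1 `COc1ccc(/C=C/c2cc(OC)cc(OC)c2/C=C/C(=O)c2ccc(Br)cc2)cc1` gives 8.3 ug/mL and compound 2 `COc1ccc(/C=C/c2cc(OC)cc(OC)c2/C=C/C(=O)c2ccc(Cl)cc2)cc1` gives 6.4 ug/mL. Going by the values given here, these are the only two numbers so far, and they cannot be told apart: replacing bromo with chloro produces a 1.3-fold lower number from compound 1 to compound 2 (0.11 log units; within the scatter). Compound 2 therefore stands alongside compound 1, not clearly ahead of it.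

Compound 3 `COc1ccc(/C=C/c2cc(OC)cc(OC)c2/C=C/C(=O)c2ccc(OC)cc2)cc1` keeps the shared core and has methoxy in place of chloro on an aromatic carbon, para to a large group (methoxy in place of chloro on an aromatic carbon). In other words, 4-chlorophenyl becomes 4-methoxyphenyl. Among the compounds with values here, the only measured step at this place is the one from compound 1 to compound 2, and it involves a different swap, so it is a limited guide. On that evidence, no shift beyond the scatter is expected in this assay. The expected change is a 1.1-fold higher number from compound 2 to compound 3 (0.04 log units; within the scatter). Compound 3 is estimated at 7 ug/mL, with an expected range of 3 ug/mL to 16 ug/mL.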

Compound 3, half-maximal inhibitory concentration: 4.5 ug/mL
Compound 3: the middle estimate sits 1.6-fold (0.19 log units) above what was measured, within the range that was stated.
By their numbers in this assay, from the lowest: compounds 3, 2 and 1 (each within the scatter of the next).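

In this assay, methoxy in place of chloro gives a 1.4-fold lower number from compound 2 to compound 3 (0.15 log units; within the scatter), and methoxy in place of bromo gives a 1.8-fold lower number from compound 1 to compound 3 (0.27 log units; within the scatter). This position, para to a large group, has now carried three different groups without any step leaving the scatter, even though methoxy differs from the two halogens in having two heavy atoms and a hydrogen-bond acceptor. The data offer no measurement that bears on why these three compounds cannot be told apart.

From the compounds shown here alone, whether a different kind of group here, such as an amine, a carboxylic acid or a longer chain, would move the number beyond the scatter remains open. Also open, going by these compounds, is what a plain phenyl, with only hydrogen at this position, would give against these three compounds.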